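The source may report more compounds than this note shows. Statements on the series, on what has been measured and on what is new or still open speak of the compounds shown alone.

Compound 1 `Cc1cccc(NC(=O)c2cccc(/C=C3\CC(=O)N(c4ccccc4)C3=O)c2)c1` gives > 100000 nM in an ADME assay on HCT-116 cells (Homo sapiens) for cytotoxicity, read by MTT assay, with a stated time of 72 h (on this read-out higher numbers stand for weaker inhibition and lower numbers for stronger inhibition), a limit of the assay rather than a number.
Compound 2 `COc1cc(NC(=O)c2cccc(/C=C3\CC(=O)N(c4ccccc4)C3=O)c2)cc(OC)c1OC` gives > 100000 nM in this assay, again a limit.
Compound 3 `CCCCCN1C(=O)C/C(=C\c2cccc(C(=O)NCCCC)c2)C1=O` gives > 100000 nM in this assay, also a limit.

Compound 1 therefore stands where every measured compound stands: at the limit of > 100000 nM in this assay, at which 3 of the 3 values shown sit, with no number to separate it from compound 2 or compound 3. Among the measured compounds shown here, no step between measured compounds is available, so nothing in the data points to a change in either direction beyond the scatter.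

Compound 4 `O=C(c1cccc(/C=C2\CC(=O)N(c3ccccc3)C2=O)c1)N1CCCC1` differs from compound 1 by pyrrolidin-1-yl in place of (3-methylphenyl)amino on a carbonyl carbon. In this assay compound 4 is expected to remain near the limit, with an estimated step that the limit leaves unreadable from compound 1 to compound 4. Compound 4 is estimated at 150000 nM, with an expected range from 50000 nM to 500000 nM.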

Compound 4, half-maximal inhibitory concentration: > 100000 nM
Compound 4: a limit, no number (the forecaster's own chance of this, stated with the estimate: 85%); the middle value is on the limit's open side.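

No step can be read from compound 1 to compound 4 in this assay, since both values are limits and not numbers: the limit of > 100000 nM in this assay, at which 4 of the 4 values shown sit.

The compounds shown leave open how far pyrrolidin-1-yl and (3-methylphenyl)amino on a carbonyl carbon really differ, and whether any compound of this kind gives a readable value.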